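Ring size swap on the amide of compound 3

The source may report more compounds than this note shows. Statements on the series, on what has been measured and on what is new or still open speak of the compounds shown alone.

Measured so far:
- Compound 1 `CN1CCN(c2nccn3cc(C(=O)N4CCCC(c5ccccc5)C4)nc23)CC1` gives 1090 nM
- Compound 2 `CCCCN(C)c1cncc(C(=O)NC2CCCCCC2)n1` gives 30 nM
- Compound 3 `O=C(NC1CCCCCC1)c1cnc(N2CCCCC2)cn1` gives 8 nM

In a functional assay on CHO cells for antagonist activity at metabotropic glutamate receptor 1 (Rattus norvegicus), read by FLIPR (on this read-out lower numbers stand for stronger inhibition and higher numbers for weaker inhibition), compound 3 holds the lowest of the three numbers. Its nearest neighbour is compound 2, which gives 30 nM, a gap that lies beyond the usual scatter. Compound 1, which gives 1090 nM, sits far above both.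

Compound 4 `C[C@H]1CC[C@H](NC(=O)c2cnc(N3CCCCC3)cn2)CC1` has not yet been measured in this assay. It differs from compound 3 in one place: 4-methylcyclohexyl in place of cycloheptyl on an amide-type nitrogen. The two share the same atoms, joined differently, and neither the donor count nor the acceptor count changes. Within the data shown here, only one measured step is directly relevant, and it is not a step between compounds that differ in one place, so no measured step can guide this particular change. In this assay the expectation is a small step for compound 4, likely within or close to the scatter, of size a 1.9-fold higher number from compound 3 to compound 4 (0.27 log units; within the scatter). Compound 4 is therefore estimated at 15 nM, with a range from 4 nM to 60 nM.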

Compound 4, inhibition constant in the metabotropic glutamate receptor 1 assay: 3 nM
Estimate against measurement, compound 4: 5.0-fold (0.70 log units) above; the whole stated range lies above it.
By their numbers in the metabotropic glutamate receptor 1 assay, from the lowest: compound 4; then compound 3; then compound 2; then compound 1.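

In the metabotropic glutamate receptor 1 assay, replacing cycloheptyl with 4-methylcyclohexyl on the amide-type nitrogen gives a 2.7-fold lower number from compound 3 to compound 4 (0.43 log units; beyond the scatter), so this position accepts a change of ring with no loss and with a modest gain. Until now this position offered no comparison, since compound 2 and compound 3 both carry cycloheptyl there. In a physicochemical assay for lipophilicity (a lower number here means a more polar compound, a higher number a more lipophilic compound), compound 3 gives 3.9 and compound 4 gives 4.4 as the distribution coefficient. The gain comes with a more lipophilic compound, as measured in the physicochemical assay: the measured distribution coefficient of compound 3, 3.9, and of compound 4, 4.4, a number 0.50 log units higher (beyond the scatter)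

This single step cannot separate the change in ring size from the added methyl group, and it cannot show whether the number in the metabotropic glutamate receptor 1 assay follows lipophilicity at this position. From the compounds shown here alone, it remains open how plain cyclohexyl, 4-hydroxycyclohexyl or the other stereoisomer of 4-methylcyclohexyl would behave on the same nitrogen.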